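Pyrimidinylthio ketones: compound 4 from compound 2

The source may hold more compounds than are shown below. What is called first, only, known or untested is meant among the compounds shown, and "the series" means these compounds.

Measured so far:
compound 1 `COc1ccc(-c2nc(C)c(C(=O)CSc3nc(N)c(C#N)c(-c4ccc(Cl)cc4)n3)s2)cc1` gives 23.1%
compound 2 `COc1ccc(-c2nc(C)c(C(=O)CSc3nc(-c4cccc(OC)c4)c(C#N)c(=O)[nH]3)s2)cc1` gives 43.2%
compound 3 `COc1cccc(-c2nc(SCC(=O)c3sc(-c4ccccc4)nc3C)[nH]c(=O)c2C#N)c1` gives 80.3%

In a functional assay on U-87MG ATCC cells for antiproliferative activity against U-87 MG (Homo sapiens), read by MTT assay, with a stated time of 48 h, tested at 50 uM (a higher number here means a weaker effect of the compound at the concentration tested, a lower number a stronger effect), compound 2 stands second highest of the three; compound 1 lies lower and compound 3 higher, both beyond the scatter. Compound 4 `COc1ccc(-c2nc(C)c(C(=O)CSc3nc(-c4ccc(Cl)c(Cl)c4)c(C#N)c(=O)[nH]3)s2)cc1` differs from compound 2 by 3,4-dichlorophenyl in place of 3-methoxyphenyl on an aromatic carbon. Among the compounds with values here, the only measured step, a number 37.1 percentage points higher from compound 2 to compound 3 (beyond the scatter), concerns a change elsewhere in the structure and does not bear on this exchange. Compound 1 carries a chlorophenyl on a different core and shows the lowest value, which suggests, weakly, that chlorine substitution is not associated with a higher number. For compound 4 a small step downward, within the scatter, is therefore expected: a number 5.2 percentage points lower from compound 2 to compound 4 (within the scatter). The estimate for compound 4 is 38%, with a range from 20% to 58%.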

Compound 4, a percentage reported as activity, at one concentration (the size of the read-out at that concentration, not a potency): 78.4%
Compound 4: middle estimate off by 40.4 percentage points, on the low side, outside the stated range (above it).
By their numbers in this assay, from the lowest: compound 1; then compound 2; then compounds 4 and 3 (each within the scatter of the next).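

In this assay, 3,4-dichlorophenyl in place of 3-methoxyphenyl gives a number 35.2 percentage points higher from compound 2 to compound 4 (beyond the scatter), so the effect at the concentration tested depends strongly on the aryl group at this carbon, next to the ring nitrogen and ortho to a cyano group. The chlorophenyl of compound 1 sits on a different core and gave no reading of this position. Nothing available explains the loss of effect. On these data alone, the exchange removes methoxy and adds two chlorines at once, so their separate contributions stay open. Also open, as far as these compounds go, is how a phenyl bearing a single chlorine, an amine or a carboxylic acid would behave here.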